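Aryl swap at the imine carbon: compound 3 to compound 4

This account rests on a few compounds, and the source may have more. Where it says the series, first, only, none or still open, it means among the compounds named here.

In an assay on CHO-K1 cells for displacement of a labelled ligand from adenosine receptor A1 (Homo sapiens), read by scintillation counting, with a stated time of 60 min (on this read-out lower numbers stand for stronger inhibition and higher numbers for weaker inhibition), compound 3 `Nc1nc(N/N=C/c2ccc[nH]2)nc2c1ncn2[C@@H]1O[C@H](CO)[C@@H](O)[C@H]1O` gives 8 nM, the higher of the two numbers shown. Compound 2 `Nc1nc(N/N=C/c2cccnc2Cl)nc2c1ncn2[C@@H]1O[C@H](CO)[C@@H](O)[C@H]1O` gives 4.6 nM; a 1.7-fold higher number from compound 2 to compound 3 (0.24 log units; within the scatter). Compound 1 `CC(=O)Nc1ccc(/C=N/Nc2nc(N)c3ncn([C@@H]4O[C@H](CO)[C@@H](O)[C@H]4O)c3n2)cc1` sits at a limit of the assay, > 10000 nM. The change to compound 4 `N#Cc1ccc(/C=N/Nc2nc(N)c3ncn([C@@H]4O[C@H](CO)[C@@H](O)[C@H]4O)c3n2)cc1` is 4-cyanophenyl in place of 1H-pyrrol-2-yl on a carbon with a double bond to nitrogen. The measured steps that bear on it both exchange a substituted six-membered aromatic ring of carbon only for a heteroaryl: an at least 2100-fold lower number from compound 1 to compound 2 (3.33 log units; beyond the scatter) and an at least 1200-fold lower number from compound 1 to compound 3 (3.09 log units; beyond the scatter). Compound 4 returns to a substituted ring of carbon only, as in compound 1, so a large rise in this assay is expected, a 380-fold higher number from compound 3 to compound 4 (2.57 log units; beyond the scatter), with a real chance of a limit. The estimate for compound 4 is 3000 nM, within 200 nM to 30000 nM.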

Compound 4, inhibition constant: 4.1 nM
Compound 4: middle estimate off by 730-fold (2.86 log units), on the high side; the whole stated range lies above it.
By their numbers in this assay, from the lowest: compounds 4, 2 and 3 (each within the scatter of the next). At a limit, above all of these: compound 1.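

In this assay, a six-membered aromatic ring of carbon only on this carbon is no barrier in itself, as 4-cyanophenyl shows a 2.0-fold lower number from compound 3 to compound 4 (0.29 log units; within the scatter) and a 1.1-fold lower number from compound 2 to compound 4 (0.05 log units; within the scatter). Among these compounds, the rise in compound 1 therefore goes with the acetamido group and not with the ring type, with cyano in place of acetamido giving an at least 2400-fold lower number from compound 1 to compound 4 (3.38 log units; beyond the scatter). Compound 1 stands at a limit, so this step gives a bound and not a size: the limit of > 10000 nM in this assay, at which 1 of the 4 values shown sits.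

Open, as far as these compounds go, is whether a phenyl ring carrying an amine or a carboxylic acid in place of the nitrile would group with compound 4 or with compound 1.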